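Fluorinated tail length in a thiochromane acid series

A few compounds are considered here, and "the series" means these few. Any claim that something is new, unique, unknown or untested is made for them only; others in the source may bear on it.

Working notes on three measured compounds and one to come, all on the shared core of compound 1, `C[C@]1(c2ccc(O)cc2)CSc2cc(O)ccc2[C@H]1CCCCCCCCC(CCCC(F)(F)C(F)(F)F)C(=O)O`, differing only in the fluorinated tail of the acid side chain. In a functional assay on the whole organism for antagonist activity, with Mus musculus as the target, at a dose of 3 mg/kg by the oral route (a higher number here means a stronger effect of the compound at the dose given, a lower number a weaker effect), compound 1 gives 41%, the lowest of the two numbers available. Compound 2, `C[C@]1(c2ccc(O)cc2)CSc2cc(O)ccc2[C@H]1CCCCCCCC(CCCC(F)(F)C(F)(F)F)C(=O)O`, has no result in this assay; its entry reads "not determined" (no result reported). Compound 3, `C[C@]1(c2ccc(O)cc2)CSc2cc(O)ccc2[C@H]1CCCCCCCCC(CCC(F)(F)C(F)(F)C(F)(F)C(F)(F)F)C(=O)O`, gives 63% in this assay, a gap to compound 1 that lies beyond the usual scatter. Within the data shown here, no pair among the measured compounds differs in a single place, so no computed step is available.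

Compound 4, `C[C@]1(c2ccc(O)cc2)CSc2cc(O)ccc2[C@H]1CCCCCCCCC(CCCC(F)(F)C(F)(F)C(F)(F)C(F)(F)F)C(=O)O`, is compound 1 with one change: 1,1,2,2,2-pentafluoroethyl in place of fluoro on a saturated chain carbon bound to two fluorine atoms and a saturated chain carbon. Compound 3 also carries a 1,1,2,2,2-pentafluoroethyl on a saturated chain carbon bound to two fluorine atoms, and its value of 63% is the only pointer to the direction of this change. On that basis an upward step is expected for compound 4, estimated at a number 17 percentage points higher from compound 1 to compound 4 (beyond the scatter), of a size that should clear the scatter. The estimate for compound 4 in this assay is therefore 58%, with a range from 40% to 75%, the lower end acknowledging that a single comparison supports it.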

Compound 4, a percentage reported as inhibition, in the whole organism at one dose (the size of the read-out at that dose, not a potency): 61%
Estimate against measurement, compound 4: 3 percentage points below; low and high end bracket the measured number.
By their numbers in this assay, from the lowest: compound 1; then compounds 4 and 3 (each within the scatter of the next).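

Pentafluoroethyl on this chain carbon gives the first comparison in the series that isolates a single change: with 1,1,2,2,2-pentafluoroethyl in place of fluoro on a saturated chain carbon bound to two fluorine atoms and a saturated chain carbon, this assay shows a number 20 percentage points higher from compound 1 to compound 4 (beyond the scatter). Among these compounds, no earlier pair differed in one place only, so this is the first direct link between extending the fluorinated end of the tail at this carbon and a larger effect, though it is a difference in effect size at one oral dose and not in potency. No accompanying data bear on the origin of this step.

Still open, going by these compounds, is whether a longer perfluorinated group, such as nonafluorobutyl on this same carbon, would raise the read-out further, and whether a plain ethyl group without fluorine at this place would match 1,1,2,2,2-pentafluoroethyl. The length of the saturated chain joining the shared core to the carbon bearing the carboxylic acid also remains unresolved, with compound 2 providing no number in this assay.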